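This account rests on a few compounds, and the source may have more. Where it says the series, first, only, none or still open, it means among the compounds named here.

In a functional assay on A549 cells (Homo sapiens) for cytotoxicity (on this read-out lower numbers stand for stronger inhibition and higher numbers for weaker inhibition), compound 1 `CC(C)CC[C@H](O)CCCCCCCCC[C@@H]1N[C@@H](CO)[C@@H]1O` gives > 2 ug/mL, which is a limit of the assay and not a number. Compound 2 `CCCCCCCCCCCCCC[C@@H]1N[C@@H](CO)[C@@H]1O` gives 0.34 ug/mL. Compound 3 `CCCCCCCCCCCCCC[C@@H]1N[C@H](CO)[C@H]1O` gives 1.97 ug/mL, the higher of the two true numbers and so the weaker result of that pair.

Compound 4 `CCCCCCCCCCCCCC[C@H]1N[C@@H](CO)[C@H]1O` is a further stereoisomer of compound 3: the two compounds have the same atoms and bonds and differ only in configuration as drawn: 2 of 3 stereo elements differ; a stereocentre at a saturated ring carbon is drawn S in compound 3 and R in compound 4; a stereocentre at a saturated ring carbon is drawn R in compound 3 and S in compound 4. No atom or bond changes, only the way two ring carbons are drawn in space.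

The closest guide is a 5.8-fold higher number from compound 2 to compound 3 (0.76 log units; beyond the scatter), a step that also inverts two stereocentres. That gap can only come from configuration because of the fact that compounds 2 and 3 differ only in the configuration as drawn. For the measured compounds named here, it shows that such a change can matter in this assay, though it is only one example and does not fix the direction for a different pair of centres. The other measured step, an at least 5.8-fold lower number from compound 1 to compound 2 (0.76 log units; beyond the scatter), changes the chain, which stays the same here, so it bears little on this comparison.

A change of similar or smaller size is therefore expected, with only a slight lean towards stronger inhibition. The expected change is a 2.0-fold lower number from compound 3 to compound 4 (0.29 log units; within the scatter). For compound 4 the estimated value is 1 ug/mL, with an expected range from 0.3 ug/mL to 3 ug/mL.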

Compound 4, half-maximal inhibitory concentration: 1.38 ug/mL
Compound 4: the middle estimate sits 1.4-fold (0.14 log units) below what was measured; measured number inside the range.
By their numbers in this assay, from the lowest: compound 2; then compounds 4 and 3 (each within the scatter of the next). At a limit, above all of these: compound 1.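

Among the stereoisomers, the result separates two kinds of inversion at the ring carbons. In this assay, one inversion of two ring carbons gives no readable difference: a 1.4-fold lower number from compound 3 to compound 4 (0.15 log units; within the scatter), so compounds 3 and 4 cannot be told apart in this test, even though the same kind of double inversion gave a clear gap for the earlier pair. The new compound also adds a second comparison with compound 2, a 4.1-fold higher number from compound 2 to compound 4 (0.61 log units; beyond the scatter), which leaves compound 2 as the most potent of the four compounds shown, and this gap must come from the three-dimensional arrangement alone, because nothing else separates the two structures: the fact that compounds 2 and 4 differ only in the configuration as drawn

Every stereoisomer pair shown inverts two ring carbons together, so what a single ring carbon contributes on its own stays open, as does the result of inverting the third stereocentre. On these data alone, it also remains unknown whether the same ranking of these arrangements would hold with a longer chain, or with a carboxylic acid on the shared core.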